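A few compounds are considered here, and "the series" means these few. Any claim that something is new, unique, unknown or untested is made for them only; others in the source may bear on it.

The measured compounds:

Compound 1, `CC(=O)c1c(C)nc2c(OCc3ccccc3)cccn12`, gives 9%.
Compound 2, `Cc1nc2c(OCc3ccccc3)cccn2c1CS(C)(=O)=O`, gives 0%.

Both numbers come from a functional assay on the whole organism (stomach) for inhibition, with Canis familiaris (Canis lupus familiaris) as the target, at a dose of 5 mg/kg by the intravenous route; on this read-out lower numbers stand for a weaker effect and higher numbers for a stronger effect at the one dose given. Compound 2 has the lower of the two numbers shown, but the difference between it and compound 1 is a number 9 percentage points lower from compound 1 to compound 2 (within the scatter), so neither compound can be called stronger or weaker than the other on this read-out. Among the compounds with values here, the one measured step, from acetyl to (methylsulfonyl)methyl on an aromatic carbon, left the inhibition essentially unchanged.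

Compound 3, `Cc1nc2c(OCc3ccccc3)cccn2c1CC(=O)O`, has not yet been measured. It differs from compound 2 as follows: carboxy in place of methylsulfonyl on a saturated chain carbon bound to an aromatic carbon. Cut one bond further out, this reads as (methylsulfonyl)methyl to carboxymethyl, so the changed position is the same one that was altered in the step from compound 1 to compound 2.

Within the data shown here, only that step bears on the new change, and it was within the scatter. Among the measured compounds shown here, since both measured compounds sit at the low end of the read-out, and the single comparable step moved nothing beyond the scatter, the expectation for compound 3 is a step of a number 5 percentage points higher from compound 2 to compound 3 (within the scatter), that is, no change beyond the scatter. Compound 3 is therefore estimated to give 5%, with a plausible range from 0% to 20%.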

Compound 3, a percentage reported as inhibition, in the whole organism at one dose (the size of the read-out at that dose, not a potency): 24%
Compound 3: the middle estimate sits 19 percentage points below what was measured; measured number above the stated range.
By their numbers in this assay, from the lowest: compounds 2 and 1 (each within the scatter of the next); then compound 3.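

In this assay, this position proves able to register a change of group: carboxy in place of methylsulfonyl on a saturated chain carbon bound to an aromatic carbon gives a number 24 percentage points higher from compound 2 to compound 3 (beyond the scatter), whereas the earlier change at the same place stayed within the scatter. Carboxymethyl also separates from acetyl on the aromatic carbon, with a number 15 percentage points higher from compound 1 to compound 3 (beyond the scatter), which makes compound 3 the strongest of the three on this read-out, though both of its steps remain modest. The data shown offer no explanation for why carboxy stands apart from the other two groups.

The three compounds cannot show whether this rise depends on the carboxy group itself or on its distance from the core, and a longer chain ending in the same group, or an amide or an amine at that place, would help separate these possibilities. Because the read-out reflects a single dose, it also leaves open how potent compound 3 is and how its effect would change at other doses.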